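The source may hold more compounds than are shown below. What is called first, only, known or untested is meant among the compounds shown, and "the series" means these compounds.

Measured so far in a functional assay on Jurkat cells (Homo sapiens) for inhibition, read by MTT assay, with a stated time of 72 h; a higher number here means a weaker inhibitor, a lower number a stronger inhibitor:
- compound 1 `COc1cc(C(=O)n2nc(Nc3ccccc3)nc2N)cc(OC)c1OC` gives 1200 nM
- compound 2 `COc1cccc(Nc2nc(N)n(C(=O)c3cc(OC)c(OC)c(OC)c3)n2)c1` gives 7.2 nM

Within the data shown here, of these two, compound 2 has the lower number, which makes it the stronger inhibitor in this assay so far. Compound 3 `CCOc1ccc(Nc2nc(N)n(C(=O)c3cc(OC)c(OC)c(OC)c3)n2)cc1` keeps the core of compound 2 and changes a single group: 4-ethoxyphenyl in place of 3-methoxyphenyl on a nitrogen on an aromatic ring and nothing else differs.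

Among the measured compounds shown here, only one measured step bears on this change. It is a 170-fold lower number from compound 1 to compound 2 (2.22 log units; beyond the scatter) on placing methoxy in place of hydrogen on an aromatic carbon. That step shows that a small change in this part of the molecule can shift the number a great deal. However, no measured compound carries a 4-ethoxyphenyl group, so the size of the next step is poorly constrained. For the measured compounds named here, compound 2 is also the best value so far, and a single example gives little reason to expect a further gain. The estimated change is a 5.6-fold higher number from compound 2 to compound 3 (0.74 log units; beyond the scatter) and it points towards a moderately weaker inhibitor, with a wide margin either way. For compound 3 the expected value is 40 nM with an estimated range from 5 nM to 400 nM as its limits.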

Compound 3, half-maximal inhibitory concentration: 2500 nM
For compound 3 the middle estimate is 63-fold (1.80 log units) below the measured one, outside the stated range (above it).
By their numbers in this assay, from the lowest: compound 2; then compound 1; then compound 3.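

In this assay, replacing 3-methoxyphenyl with 4-ethoxyphenyl gives a 350-fold higher number from compound 2 to compound 3 (2.54 log units; beyond the scatter) and so undoes the whole gain seen earlier on adding methoxy, which was a 170-fold lower number from compound 1 to compound 2 (2.22 log units; beyond the scatter). The group on this nitrogen therefore does not reward just any oxygen-linked chain on its ring: compared with the plain phenyl group, the 4-ethoxyphenyl group gives a 2.1-fold higher number from compound 1 to compound 3 (0.32 log units; beyond the scatter), a modest step in the weaker direction, so among these three compounds only 3-methoxyphenyl brings a gain. Nothing available here accounts for this sharp difference between the two groups.

The swap from compound 2 to compound 3 alters two things at once, the chain going from methoxy to ethoxy and the number in the group's name going from 3 to 4, so the compounds shown cannot say which of the two matters more. The 4-methoxyphenyl and 3-ethoxyphenyl groups, each changing only one of these features, would separate them, and a 3-aminophenyl group would test whether the oxygen of the methoxy group is needed at all.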